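The compounds below may be only part of what the source reports. "The series", "measured", "known", "first", "only" and "open" are said of these compounds alone.

Compound 1 `CCCCCCCCOC(=O)C(O)Cn1cnc2c(N)ncnc21` carries an octyl group on the oxygen next to the carbonyl group; in a functional assay on HeLa cells (Homo sapiens) for cytotoxicity (a higher number here means that more compound is tolerated, a lower number that less compound is tolerated), compound 1 gives 100 ug/mL. Compound 2 `Nc1ncnc2c1ncn2CC(O)C(=O)OC1CCCCC1` carries a cyclohexyl group in that place, and in this assay compound 2 gives 100 ug/mL, so the step of no change at the digits printed from compound 1 to compound 2 (within the scatter). Compound 3 `CC(C)(C)OC(=O)C(O)Cn1cnc2c(N)ncnc21` carries a tert-butyl group there. For compound 3 in this assay only a limit is known, > 400 ug/mL, which is a limit of the assay and not a number (the limit of > 400 ug/mL in this assay, at which 1 of the 3 values shown sits). The steps of an at least 4.0-fold higher number from compound 1 to compound 3 (0.60 log units; beyond the scatter) and an at least 4.0-fold higher number from compound 2 to compound 3 (0.60 log units; beyond the scatter) therefore both point toward more compound being tolerated with tert-butyl.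

Compound 4 `CCC(C)OC(=O)C(O)Cn1cnc2c(N)ncnc21` has not yet been measured. It differs from compound 3 by sec-butyl in place of tert-butyl on an oxygen next to a carbonyl group. The two steps toward tert-butyl bear on this change: the octyl and cyclohexyl esters sit at the lower number, while the tert-butyl ester reaches the limit. A sec-butyl group is expected to fall between those cases, so in this assay a step of an at least 1.6-fold lower number from compound 3 to compound 4 (0.20 log units; that floor lies within the scatter) is expected, at most modest and toward a lower number, if beyond the scatter at all. Compound 4 is accordingly estimated at 250 ug/mL, with a range from 100 ug/mL to 400 ug/mL.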

Compound 4, minimum cytotoxic concentration: > 400 ug/mL
Compound 4: no number, only a limit; the forecaster's own chance of this, stated with the estimate: 40%; middle value at least 1.6-fold (0.20 log units) away from the limit.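

Compound 4 shows that in this assay the gain over the larger esters does not belong to tert-butyl alone: on an oxygen next to a carbonyl group, sec-butyl also gives an at least 4.0-fold higher number from compound 2 to compound 4 (0.60 log units; beyond the scatter), and likewise an at least 4.0-fold higher number from compound 1 to compound 4 (0.60 log units; beyond the scatter). So two differently branched butyl esters with the same count of carbons part from the octyl and cyclohexyl esters in the same direction. Compound 3 and compound 4 both stand at a limit and not at a number, so the step between them cannot be read: the limit of > 400 ug/mL in this assay, at which 2 of the 4 values shown sit.

From the compounds shown here alone, how far beyond that limit either compound lies remains open. Also open, going by these compounds, is where a straight butyl chain, a cyclopentyl group or the free carboxylic acid would fall.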